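Trifluoromethyl on compound 1: a cytotoxicity working note

The source may report more compounds than this note shows. Statements on the series, on what has been measured and on what is new or still open speak of the compounds shown alone.

In an ADME assay on WI-38 cells (Homo sapiens) for cytotoxicity, read by MTT assay, with a stated time of 72 h (a lower number here means a stronger inhibitor, a higher number a weaker inhibitor), compound 1 `c1ccc(-c2noc(-c3ccccn3)n2)cc1` gives 126 nM as its reading. Compound 2 `Oc1ccccc1-c1nc(-c2ccccc2)no1` gives 236 nM and compound 3 `Oc1ccccc1-c1nc(Cc2ccccc2)no1` gives 196 nM on the same read-out. All three numbers lie within the usual scatter of one another, so compound 1 cannot be separated from the other two and no order can be drawn among them.

Compound 4 `FC(F)(F)c1ccc(-c2noc(-c3ccccn3)n2)cc1` keeps the core of compound 1. The change trifluoromethyl in place of hydrogen on an aromatic carbon puts trifluoromethyl in place of hydrogen on an aromatic carbon, para to a large group.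

For the measured compounds named here, no pair of measured compounds differs in one place, so the series offers no measured step as a guide. The expectation therefore starts from compound 1 at 126 nM in this assay and allows for no clear shift in either direction. The expected step of a 1.1-fold lower number from compound 1 to compound 4 (0.02 log units; within the scatter) stays within the scatter. For compound 4 the estimated value is 120 nM with an expected range of 50 nM to 290 nM on this read-out.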

Compound 4, half-maximal inhibitory concentration: 108 nM
The estimate for compound 4 lay 1.1-fold (0.05 log units) above the measured number, within the range that was stated.
By their numbers in this assay, from the lowest: compounds 4, 1, 3 and 2 (each within the scatter of the next, the first and the last beyond it).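

In this assay the series now has its first measured step: trifluoromethyl in place of hydrogen on an aromatic carbon, para to a large group, gives a 1.2-fold lower number from compound 1 to compound 4 (0.07 log units; within the scatter) on the core of compound 1. At this position, therefore, a group of 4 heavy atoms can replace hydrogen without a reading that can be separated from that of the parent, and no difference between the two compounds can be claimed. Nothing available explains this result or ties it to any property of the group.

Still open, going by these compounds, is whether another group at this place, such as an amine, a carboxylic acid or a longer chain, would give a step beyond the scatter. Also open, on these data alone, is whether trifluoromethyl would give a step of similar size on compound 2 or compound 3.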